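Trimming the amide nitrogen in the aminomethyl cyclopropane series

The compounds below may be only part of what the source reports. "The series", "measured", "known", "first", "only" and "open" are said of these compounds alone.

Going by the values given here, compound 1 `C=CCN(CC=C)C(=O)[C@@]1(c2ccsc2)C[C@H]1CN` is the only member of the set with a measured number in an assay on HEK293 cells for inhibition of sodium-dependent dopamine transporter (Homo sapiens); a higher number here means a weaker inhibitor, a lower number a stronger inhibitor; in that assay compound 1 gives 8300 nM. Compound 2 `CCN(CC)C(=O)[C@@]1(c2ccc(Cl)s2)C[C@H]1CN` gives > 10000 nM in this assay, which is a limit of the assay and not a number. Among the compounds with values here, that one of the two recorded values sits at the limit of > 10000 nM in this assay, at which 1 of the 2 values shown sits, leaves compound 1 without any measured neighbour, so no step between measured compounds can be drawn on, and the expectation for a new analogue rests on the structural change alone.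

Compound 3 `C=CCN(C)C(=O)[C@@]1(c2ccsc2)C[C@H]1CN` differs from compound 1 by hydrogen in place of vinyl on a saturated chain carbon bound to an amide-type nitrogen; cut one bond further out, the change reads allyl to methyl. Compound 1 already gives a high half-maximal inhibitory concentration, and removing part of one amide substituent is expected to move it, if at all, toward weaker inhibition: the step from compound 1 to compound 3 is estimated at a 1.4-fold higher number from compound 1 to compound 3 (0.16 log units; within the scatter), not clearly beyond the scatter. Compound 3 is expected to give 12000 nM in this assay, within 4000 nM to 35000 nM, with a real chance that only a limit is reported.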

Compound 3, half-maximal inhibitory concentration: > 10000 nM
Compound 3: a limit, no number; the forecaster's own chance of this, stated with the estimate: 55%; the middle value is on the limit's open side.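

In this assay compound 3 gives > 10000 nM, which is a limit of the assay and not a number. Cutting allyl to methyl on the amide-type nitrogen amounts to an at least 1.2-fold higher number from compound 1 to compound 3 (0.08 log units; that floor lies within the scatter), so only a floor can be read for this step, its true size stays unknown, and a real loss of inhibition is neither shown nor excluded. What the change does show is that the smaller methyl substituent brings no recovery into the measurable range, and the series now sits mostly against the ceiling of this assay, leaving little room to rank further changes at this position: the limit of > 10000 nM in this assay, at which 2 of the 3 values shown sit.

Still open, as far as these compounds go, is whether a larger group on this nitrogen, such as a benzyl or cyclopropylmethyl substituent, or a piperidine amide that ties both substituents into one ring, would give a clearly lower number than compound 1. Also open, from the compounds shown here alone, is whether the allyl group itself matters or any longer chain, such as n-propyl, would serve equally well, since the saturated counterpart of allyl would separate chain length from the double bond.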